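Compound 3: a 2,3-dihydroxypropoxy group on compound 2

The source may hold more compounds than are shown below. What is called first, only, known or untested is meant among the compounds shown, and "the series" means these compounds.

In a functional assay on CWR22R cells (Homo sapiens) for antiproliferative activity, read by CCK-8 assay, with a stated time of 6 days (a higher number here means a weaker inhibitor, a lower number a stronger inhibitor), compound 1 (`CC(=O)c1cc(C(=O)N[C@@H](C)Cn2ccc(-c3cc(F)c(C#N)c(Cl)c3)n2)n[nH]1`) gives > 30000 nM which is a limit of the assay and not a number. For the measured compounds named here, compound 2 (`C[C@@H](Cn1ccc(-c2ccc(C#N)c(Cl)c2)n1)NC(=O)c1ccccc1`) has the entry "not determined" (no result reported) in the same test, so its place on the scale is unknown and the series offers no measured step to use as a guide. Compound 3 (`C[C@@H](Cn1ccc(-c2ccc(C#N)c(Cl)c2)n1)NC(=O)c1cccc(OCC(O)CO)c1`) has yet to be measured. The change is 2,3-dihydroxypropoxy in place of hydrogen on an aromatic carbon and consists of 2,3-dihydroxypropoxy in place of hydrogen on an aromatic carbon, meta to a large group. With no number for compound 2, the size of this step in this assay cannot be anchored. No large gain in potency is expected, and compound 3 is expected to remain a weak inhibitor because compound 1 sits at the limit of > 30000 nM in this test. In this assay the half-maximal inhibitory concentration of compound 3 is estimated at 20000 nM with an expected range of 4000 nM to 60000 nM and the result may come back only as a limit.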

Compound 3, half-maximal inhibitory concentration: > 30000 nM
Compound 3 was reported as a limit; the forecaster's own chance of this, stated with the estimate: 50%; middle value at least 1.5-fold (0.17 log units) from the limit.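

In this assay compound 3 gives > 30000 nM, which is a limit of the assay and not a number. For the compounds shown here, compound 2 has no number in this test, so no step from compound 2 to compound 3 can be read. The compounds shown leave open whether the 2,3-dihydroxypropoxy group changes potency at all, and how the compounds rank, with the values resting at one point: the limit of > 30000 nM in this assay, at which 2 of the 3 values shown sit.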